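This account rests on a few compounds, and the source may have more. Where it says the series, first, only, none or still open, it means among the compounds named here.

Measured compounds:
compound 1, `CC(=O)N1CCC(C(=O)N2CC[C@H](C(=O)N(C)Cc3cc(C(F)(F)F)cc(C(F)(F)F)c3)[C@@H](c3ccc(C)cc3)C2)CC1`, 0.18 nM
compound 2, `CC(=O)N1CCC(C(=O)N2CC[C@H](C(=O)N(C)Cc3cc(C(F)(F)F)cc(C(F)(F)F)c3)[C@@H](c3ccc(F)cc3C)C2)CC1`, 0.047 nM
compound 3, `CC(=O)NCC(=O)N1CC[C@H](C(=O)N(C)Cc2cc(C(F)(F)F)cc(C(F)(F)F)c2)[C@@H](c2ccc(F)cc2C)C1`, 0.043 nM

All three were run in an assay on IM-9 cells for displacement of a labelled ligand from Substance-P receptor (Homo sapiens), read by scintillation counting, with a stated time of 30 min; on this read-out lower numbers stand for stronger inhibition and higher numbers for weaker inhibition. Among the compounds with values here, compound 3 gives the lowest number of the three, but the step of a 1.1-fold lower number from compound 2 to compound 3 (0.04 log units; within the scatter) is small, so the two cannot be ordered; only compound 1 stands clearly apart, the step of a 3.8-fold lower number from compound 1 to compound 2 (0.58 log units; beyond the scatter) being the one change on the saturated ring carbon in the set.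

Compound 4, `CNC(=O)N1CC[C@H](C(=O)N(C)Cc2cc(C(F)(F)F)cc(C(F)(F)F)c2)[C@@H](c2ccc(F)cc2C)C1`, is not yet measured. It differs from compound 3 in one place: methylamino in place of acetamidomethyl on a carbonyl carbon. Within the data shown here, the only measured step at this position is the one from compound 2 to compound 3, in which a change on the same carbonyl carbon gave a 1.1-fold lower number from compound 2 to compound 3 (0.04 log units; within the scatter). That single step is the whole of the evidence for this position, and it suggests the group on that carbonyl carbon carries little of the binding. The change to compound 4 is larger, leaving behind a smaller group with no acceptor, so some widening of the uncertainty is warranted.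

Compound 4 is therefore expected to stay close to compound 3, with an expected step of a 1.4-fold higher number from compound 3 to compound 4 (0.14 log units; within the scatter). The estimate for compound 4 in this assay is 0.06 nM, with a likely range from 0.02 nM to 0.2 nM.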

Compound 4, half-maximal inhibitory concentration: 0.048 nM
For compound 4 the middle estimate is 1.3-fold (0.10 log units) above the measured one; the measured number falls inside the stated range.
By their numbers in this assay, from the lowest: compounds 3, 2 and 4 (each within the scatter of the next); then compound 1.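

In this assay, methylamino in place of acetamidomethyl on the carbonyl carbon gives a 1.1-fold higher number from compound 3 to compound 4 (0.05 log units; within the scatter), and methylamino in place of 1-acetylpiperidin-4-yl on the same carbon gives a 1.0-fold higher number from compound 2 to compound 4 (0.01 log units; within the scatter); both steps lie within the scatter. The earlier single step at this position now has company: methylamino, with 2 heavy atoms and 0 hydrogen-bond acceptors, cannot be told apart from acetamidomethyl, with 5 heavy atoms and 1 hydrogen-bond acceptor. Nothing available accounts for this flat reading.

From the compounds shown here alone, all three compounds compared here carry 4-fluoro-2-methylphenyl, so it remains open whether the position reads as flat with 4-methylphenyl on the saturated ring carbon. Also open, going by these compounds, is whether a carboxylic acid, a primary amine or a longer alkyl chain on the carbonyl carbon would hold the same number.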